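Swapping the thiophene for phenyl on a shared pyridine-type core

The source may report more compounds than this note shows. Statements on the series, on what has been measured and on what is new or still open speak of the compounds shown alone.

Measured compounds:
compound 1 `Oc1cccc(-c2cc(-c3ccc(Cl)cc3)nc(-c3cccs3)c2)c1` — 9280 nM
compound 2 `Oc1cccc(-c2cc(-c3cccs3)nc(-c3ccccc3Cl)c2)c1` — 2790 nM

The two measured compounds share one core and differ only in where the chlorine sits on one of the aryl groups. For the measured compounds named here, in a functional assay on HCT-15 cells (Homo sapiens) for cytotoxicity, read by CCK-8 assay and cell counting, with a stated time of 2 days (on this read-out higher numbers stand for weaker inhibition and lower numbers for stronger inhibition), compound 1 gives 9280 nM, the highest of the two numbers; its nearest neighbour is compound 2, and the step of a 3.3-fold lower number from compound 1 to compound 2 (0.52 log units; beyond the scatter) is the only measured step.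

Compound 3 `Oc1cccc(-c2cc(-c3ccccc3)nc(-c3ccc(Cl)cc3)c2)c1` is not yet measured. Relative to compound 1 the change is phenyl in place of thiophen-2-yl on an aromatic carbon. Going by the values given here, no measured step bears on this exchange: the single step from compound 1 to compound 2 concerns the position of the chlorine on a different ring and says nothing about the thiophen-2-yl group. With nothing to indicate a direction, the expected step of a 1.2-fold lower number from compound 1 to compound 3 (0.09 log units; within the scatter) is one within the scatter, with a wide margin for either direction. The estimate for compound 3 in this assay is therefore 7500 nM, in the range 2500 nM to 22000 nM.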

Compound 3, half-maximal inhibitory concentration: 8110 nM
For compound 3 the middle estimate is 1.1-fold (0.03 log units) below the measured one; the measured number falls inside the stated range.
By their numbers in this assay, from the lowest: compound 2; then compounds 3 and 1 (each within the scatter of the next).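

In this assay, phenyl and thiophen-2-yl on the aromatic carbon next to the ring nitrogen cannot be told apart, with a 1.1-fold lower number from compound 1 to compound 3 (0.06 log units; within the scatter) and the 4-chlorophenyl group left unchanged. For the compounds shown here, this is the first view of this exchange, and it shows that a five-membered aromatic ring with one hetero atom and a six-membered aromatic ring of carbon only give numbers within the scatter here, unlike the earlier chlorine exchange, with a 3.3-fold lower number from compound 1 to compound 2 (0.52 log units; beyond the scatter) beyond it. No measurement is available to explain this similarity.

As far as these compounds go, it remains open whether the two rings would also match alongside the 2-chlorophenyl group of compound 2, and how this position would respond to a different kind of group, such as an amine, a carboxylic acid or a longer alkyl chain. From the compounds shown here alone, the role of the 3-hydroxyphenyl group is also open, as it stands unchanged in all three compounds, so the effect of replacing its hydroxyl with a methoxy group or a hydrogen cannot be read from them.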